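Swapping one five-membered ring on a shared core

This account rests on a few compounds, and the source may have more. Where it says the series, first, only, none or still open, it means among the compounds named here.

Measured in a functional assay on A-375 cells (Homo sapiens) for antiproliferative activity; a higher number here means a weaker inhibitor, a lower number a stronger inhibitor:
Compound 1 `O=C(Nc1ccc(-c2cscn2)cc1)C1CCCN(Cc2ccc(F)c(F)c2)C1`: 880 nM
Compound 2 `O=C(Nc1ccc(-c2ccoc2)cc1)C1CCCN(Cc2ccc(F)c(F)c2)C1`: 1290 nM
Compound 3 `O=C(Nc1ccc(-c2ccco2)cc1)C1CCCN(Cc2ccc(F)c(F)c2)C1`: 1040 nM

Compound 3 cannot be told apart from the other two, since every measured step lies within the scatter: a 1.2-fold higher number from compound 1 to compound 3 (0.07 log units; within the scatter), a 1.2-fold lower number from compound 2 to compound 3 (0.09 log units; within the scatter) and a 1.5-fold higher number from compound 1 to compound 2 (0.17 log units; within the scatter). Compound 4 `O=C(Nc1ccc(-c2ccsc2)cc1)C1CCCN(Cc2ccc(F)c(F)c2)C1` is still unmeasured. It carries thiophen-3-yl in place of furan-2-yl on an aromatic carbon. No thiophene has been measured yet, but all three of these ring swaps left the number within the scatter, so no step beyond the scatter is expected in this assay. The estimated value for compound 4 is 1000 nM, with an expected range from 480 nM to 2000 nM. That estimate means an expected 1.0-fold lower number from compound 3 to compound 4 (0.02 log units; within the scatter).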

Compound 4, half-maximal inhibitory concentration: 950 nM
For compound 4 the middle estimate is 1.1-fold (0.02 log units) above the measured one; measured number inside the range.
By their numbers in this assay, from the lowest: compounds 1, 4, 3 and 2 (each within the scatter of the next).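

Thiophen-3-yl fits in with the other rings in this assay: a 1.1-fold lower number from compound 3 to compound 4 (0.04 log units; within the scatter), a 1.4-fold lower number from compound 2 to compound 4 (0.13 log units; within the scatter) and a 1.1-fold higher number from compound 1 to compound 4 (0.03 log units; within the scatter), all within the scatter. This position, on an aromatic carbon para to a large group, has now carried four five-membered aromatic rings without a step that can be told from scatter, with oxygen, sulfur, or sulfur and nitrogen in the ring. No measured evidence here offers an explanation for this.

The compounds shown leave open whether a different kind of group at this position, such as an amine, a carboxylic acid or a longer alkyl chain, would shift the number.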